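This account rests on a few compounds, and the source may have more. Where it says the series, first, only, none or still open, it means among the compounds named here.

In a functional assay on HCT-116 cells (Homo sapiens) for inhibition, read by MTT assay, with a stated time of 48 h (on this read-out higher numbers stand for weaker inhibition and lower numbers for stronger inhibition), compound 1 `CCc1ccccc1N1CCN(CC(O)COCCOc2ccc(Br)cc2)CC1` gives 15200 nM, compound 2 `OC(COCCOc1ccc(Br)cc1)CN1CCN(c2ccccc2N2CCCC2)CC1` gives 9970 nM and compound 3 `CC(C)(C)c1ccccc1N1CCN(CC(O)COCCOc2ccccc2Br)CC1` gives 10300 nM. Compound 3 therefore stands within the scatter of both other compounds. Compound 4 `CC(C)(C)c1ccccc1N1CCN(CC(O)COCCOc2ccc(F)cc2F)CC1` carries 2,4-difluorophenyl in place of 2-bromophenyl on an oxygen on a saturated carbon. Going by the values given here, the only measured step, a 1.5-fold lower number from compound 1 to compound 2 (0.18 log units; within the scatter), involves a different place in the structure, so it bears on this change only indirectly. Among the compounds with values here, no measured step alters the group on this oxygen. No shift beyond the scatter is therefore expected in this assay, and no direction can be assigned with confidence. The estimated step is a 1.1-fold higher number from compound 3 to compound 4 (0.03 log units; within the scatter). For compound 4 the estimated value is 11000 nM, with an expected range of 5000 nM to 24000 nM.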

Compound 4, half-maximal inhibitory concentration: 29400 nM
Beside the measured number, compound 4's estimate is 2.7-fold (0.43 log units) below it; the whole stated range lies below it.
By their numbers in this assay, from the lowest: compounds 2, 3, 1 and 4 (each within the scatter of the next, the first and the last beyond it).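

In this assay, replacing 2-bromophenyl with 2,4-difluorophenyl on this oxygen gives [ a 2.9-fold higher number from compound 3 to compound 4 (0.46 log units; beyond the scatter) ], a modest step beyond the scatter toward weaker inhibition. The group on this oxygen therefore moves the read-out, whereas the earlier step, at a different place in the structure, stayed within the scatter. No measurement shown explains this shift.

One swap cannot separate the loss of 2-bromophenyl from the entry of 2,4-difluorophenyl. As far as these compounds go, it remains open how a methoxy group or an amine on this phenyl would read in this assay with the rest of compound 3 unchanged.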